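Swapping the acid-bearing ring: from fluoro to chloro

This account rests on a few compounds, and the source may have more. Where it says the series, first, only, none or still open, it means among the compounds named here.

Compound 2 `Cc1c(OC[C@@H](C)COc2cc(C(=O)O)ccc2F)ccc(C(=O)CC(C)(C)C)c1O` gives 3950 nM in an assay for positive allosteric modulation of metabotropic glutamate receptor 3 (Rattus norvegicus) (a lower number here means that less compound is needed, a higher number that more compound is needed for the effect), the higher of the two numbers measured; compound 1 `COc1ccc(C(=O)O)cc1OC[C@H](C)COc1ccc(C(=O)CC(C)(C)C)c(O)c1C` gives 384 nM. Compound 3 `Cc1c(OC[C@@H](C)COc2ccc(C(=O)O)c(Cl)c2)ccc(C(=O)CC(C)(C)C)c1O` is not yet measured. It differs from compound 2 in 4-carboxy-3-chlorophenyl in place of 5-carboxy-2-fluorophenyl on an oxygen on a saturated carbon. Among the compounds with values here, the only measured step, a 10-fold higher number from compound 1 to compound 2 (1.01 log units; beyond the scatter), shows that a small change on this ring can shift the number greatly, but no measured pair matches the present change, so its direction is uncertain. Compound 3 is expected around 1500 nM, within 300 nM to 8000 nM, a step of a 2.6-fold lower number from compound 2 to compound 3 (0.42 log units; beyond the scatter) estimated from compound 2.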

Compound 3, half-maximal effective concentration: 860 nM
Estimate against measurement, compound 3: 1.7-fold (0.24 log units) above; low and high end bracket the measured number.
By their numbers in this assay, from the lowest: compound 1; then compound 3; then compound 2.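

In this assay, within the data shown here, the exchange of the whole ring gives a 4.6-fold lower number from compound 2 to compound 3 (0.66 log units; beyond the scatter), so this place on the oxygen responds to a change of both halogen and ring pattern, not only to the single swap seen earlier. The two groups match in heavy atoms, hydrogen-bond donors and acceptors, so those counts do not separate them. Nothing measured here explains the shift.

On these data alone, the halogen and the position of the carboxylic acid change together, so their separate shares remain open. Whether a bromo group or a nitrile in place of the chloro would give a similar number is also unknown.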